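The source may hold more compounds than are shown below. What is called first, only, known or untested is meant among the compounds shown, and "the series" means these compounds.

In a functional assay on the whole organism for inhibition, with Rattus norvegicus as the target, read by paw edema, with a stated time of 3 h, at a dose of 50 mg/kg (on this read-out lower numbers stand for less inhibition and higher numbers for more inhibition at the one dose given (going by the name of the read-out)), three compounds have been measured so far. Compound 1 `CC(=O)c1c(NNc2ccccc2)cc(C)oc1=O` gives 55.6% in this assay. Compound 2 `CC(=O)c1c(NNc2nc(-c3ccccc3)cs2)cc(C)oc1=O` gives 45.5% in this assay. Compound 3 `Cc1cc2nn(-c3ccccc3)c(C)c2c(=O)o1` gives 52.5% in this assay. On these numbers compound 3 stands second highest of the three, yet its gap to compound 1 and its gap to compound 2 both lie within the scatter of repeated measurements, so none of the three can be set apart from the others on this evidence.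

Compound 4 `COc1ccc(-n2nc3cc(C)oc(=O)c3c2C)cc1` differs from compound 3 in one place: methoxy in place of hydrogen on an aromatic carbon. Among the measured compounds shown here, no measured pair in the set shows a change of this kind, so there is nothing to say how such a change has behaved before. With no measured guide, the step from compound 3 to compound 4 in this assay is expected to be small, a number 2.5 percentage points lower from compound 3 to compound 4 (within the scatter), in no particular direction and not beyond the scatter. Compound 4 is therefore expected to give about 50% in this assay, with a range from 35% to 65%.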

Compound 4, a percentage reported as inhibition, in the whole organism at one dose (the size of the read-out at that dose, not a potency): 57.6%
For compound 4 the middle estimate is 7.6 percentage points below the measured one; the measured number falls inside the stated range.
By their numbers in this assay, from the lowest: compounds 2, 3, 1 and 4 (each within the scatter of the next, the first and the last beyond it).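

In this assay, among the compounds shown here, methoxy in place of hydrogen on an aromatic carbon, para to a large group, gives a number 5.1 percentage points higher from compound 3 to compound 4 (within the scatter) and so provides the first measured step at this place. The read-out at this one dose stays within the scatter when this carbon carries methoxy rather than hydrogen, so the position accepts that group without a change that can be told apart from repeat variation. Nothing measured here says why the number holds at this place.

The compounds shown leave open whether a different group at this same place, such as a chlorine atom, an amine or a carboxylic acid, would move the read-out beyond the scatter. They also leave open how methoxy would behave on another carbon of this ring.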